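The source may report more compounds than this note shows. Statements on the series, on what has been measured and on what is new or still open speak of the compounds shown alone.

Values in a functional assay on HCT-116 cells (Homo sapiens) for antiproliferative activity, read by MTT assay, with a stated time of 48 h (on this read-out lower numbers stand for stronger inhibition and higher numbers for weaker inhibition), so far:
- compound 1 `CCCCCCC(CCO)n1cnc2c(Cl)ncnc21` gives 11900 nM
- compound 2 `CCCCCCCCCCC(CCO)n1cnc2c(Cl)ncnc21` gives 4930 nM

Compound 2 holds the lower of the two numbers. Within the data shown here, the only measured step is a 2.4-fold lower number from compound 1 to compound 2 (0.38 log units; beyond the scatter) and it is modest, though beyond the scatter. It comes from butyl in place of hydrogen on a saturated chain carbon, seven bonds along the chain from an aromatic nitrogen.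

Compound 3 `CCCCCCCCCCCC(CCO)n1cnc2c(Cl)ncnc21` is not yet measured. It differs from compound 2 by methyl in place of hydrogen on a saturated chain carbon, ten or more bonds along the chain from an aromatic nitrogen in the form of methyl in place of hydrogen on a saturated chain carbon, ten or more bonds along the chain from an aromatic nitrogen.

Among the measured compounds shown here, the single step above is the only guide, and two compounds show no firm trend. Methyl is a smaller addition than butyl, so a smaller step in the same direction is expected in this assay and probably none beyond the scatter. The estimate is a 1.2-fold lower number from compound 2 to compound 3 (0.09 log units; within the scatter) as the expected change. For compound 3 the expected value is 4000 nM with an estimated range from 2000 nM to 8000 nM around it.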

Compound 3, half-maximal inhibitory concentration: 7590 nM
The estimate for compound 3 lay 1.9-fold (0.28 log units) below the measured number; measured number inside the range.
By their numbers in this assay, from the lowest: compounds 2, 3 and 1 (each within the scatter of the next, the first and the last beyond it).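

In this assay, methyl on a saturated chain carbon gives a 1.5-fold higher number from compound 2 to compound 3 (0.19 log units; within the scatter), so at this position the change does not separate compound 3 from compound 2. Pentyl in place of hydrogen gives a 1.6-fold lower number from compound 1 to compound 3 (0.20 log units; within the scatter), whereas butyl at the same carbon gave a 2.4-fold lower number from compound 1 to compound 2 (0.38 log units; beyond the scatter), so the step beyond the scatter seen with butyl is not matched with pentyl, and these three compounds support no steady trend with chain length. No measurement is available that bears on the cause of these steps.

The compounds shown leave open whether a longer chain, or a chain ending in an amine or a carboxylic acid, would move the number beyond the scatter relative to compound 2. Going by these compounds, it also remains open whether the small difference between compound 2 and compound 3 would hold in other cell types.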